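The compounds below may be only part of what the source reports. "The series", "measured", "known", "first", "only" and "open" are said of these compounds alone.

Measured compounds in a functional assay on T47D cells (Homo sapiens) for inhibition, read by sulforhodamine B assay, with a stated time of 48 h; on this read-out lower numbers stand for stronger inhibition of growth and higher numbers for weaker inhibition of growth:
Compound 1 `COc1cc(-c2nn(-c3cccc(NC(=O)Nc4ccc(Cl)c(Cl)c4)c3)cc2-c2ccncc2)ccc1Cl` gives > 50000 nM in this assay, which is a limit of the assay and not a number.
Compound 2 `O=C(Nc1cccc(-n2cc(-c3ccncc3)c(-c3ccc(Cl)c(O)c3)n2)c1)Nc1ccc(Cl)c(Cl)c1` gives 17900 nM in this assay.
Compound 3 `O=C(Nc1cccc(-n2cc(-c3ccncc3)c(-c3ccc(Cl)c(O)c3)n2)c1)Nc1cc(C(F)(F)F)cc(C(F)(F)F)c1` gives 14000 nM in this assay.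

Compound 1 thus stands at the limit of > 50000 nM in this assay, at which 1 of the 3 values shown sits. For the measured compounds named here, the one step measured in a single place, an at least 2.7-fold lower number from compound 1 to compound 2 (0.44 log units; beyond the scatter), concerns the oxygen on the aromatic ring and not the urea end. The values of compound 2 and compound 3, which differ at the urea end, lie within the scatter of each other.

Compound 4 `COc1cc(-c2nn(-c3cccc(NC(=O)Nc4ccc(Cl)c(C(F)(F)F)c4)c3)cc2-c2ccncc2)ccc1Cl` differs from compound 1 by trifluoromethyl in place of chloro on an aromatic carbon. Going by the values given here, no measured step covers this change. Since compound 1 sits at a limit, the step from compound 1 to compound 4 can only be read as an expectation that the number stays near the limit, a number no higher from compound 1 to compound 4 (the limit leaves the size open). For compound 4 the estimate in this assay is 50000 nM, expected to fall between 20000 nM and 150000 nM, with a good chance that only a limit is reported.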

Compound 4, concentration for total growth inhibition: > 32500 nM
Compound 4: a limit, no number (the forecaster's own chance of this, stated with the estimate: 65%); the middle value lies beyond the limit too.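

In this assay compound 4 gives > 32500 nM, a limit and not a number. For the compounds shown here, compound 1 gives > 50000 nM, also a limit, so no step between compound 1 and compound 4 can be read. On these data alone, what trifluoromethyl in place of chloro on an aromatic carbon does to the number stays open.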